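Alkyl branching at the imine nitrogen: compound 2 to compound 3

The source may report more compounds than this note shows. Statements on the series, on what has been measured and on what is new or still open speak of the compounds shown alone.

Measured so far:
compound 1 `CCCCC(CC)C/N=C(\NC#N)Nc1cccnc1`: > 50 mg/kg
compound 2 `CCC(C)C(C)/N=C(\NC#N)Nc1ccncc1`: 8 mg/kg

For the measured compounds named here, in a functional assay on the whole organism (blood, strain Wistar-Okamoto) with Rattus norvegicus as the target, with a stated time of 5 days (on this read-out lower numbers stand for an effect already at smaller amounts and higher numbers for an effect only at larger amounts of compound), compound 2 gives 8 mg/kg, which is the only plain number the series has so far. For compound 1 the result in this assay is a limit of the assay, > 50 mg/kg (the limit of > 50 mg/kg in this assay, at which 1 of the 2 values shown sits), so no second number stands beside compound 2.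

Compound 3 `CCC(C)(CC)/N=C(\NC#N)Nc1ccncc1` differs from compound 2 in one place: 1-ethyl-1-methylpropyl in place of 1,2-dimethylbutyl on a double-bonded nitrogen. The same six carbons are kept but joined differently, the branch point moving to the carbon attached to the double-bonded nitrogen. Going by the values given here, no step between two measured compounds is available, so nothing measured tells how large such a rearrangement is in this assay. A small step is expected, if any, and the estimated step is a 1.5-fold higher number from compound 2 to compound 3 (0.18 log units; within the scatter), not beyond the usual scatter. Compound 3 is estimated at 12 mg/kg, with a range from 4 mg/kg to 40 mg/kg.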

Compound 3, minimum effective dose: 0.5 mg/kg
Compound 3: middle estimate off by 24-fold (1.38 log units), on the high side; the measured number lies below the stated range.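

In this assay, the way the six carbons are joined on the double-bonded nitrogen turns out to matter: the rearrangement alone gives a 16-fold lower number from compound 2 to compound 3 (1.20 log units; beyond the scatter), the first step the series can offer. So 1-ethyl-1-methylpropyl and 1,2-dimethylbutyl, which match in heavy atoms, hydrogen-bond donors and acceptors and net charge, are not interchangeable at this position. Compound 1 adds no second step, as its result is a limit of the assay: the limit of > 50 mg/kg in this assay, at which 1 of the 3 values shown sits.

Still open, going by these compounds, is whether the lower number belongs to 1-ethyl-1-methylpropyl alone or extends to other groups branched in the same way, such as tert-butyl or 1-methylcyclohexyl on the double-bonded nitrogen. A single step also leaves open how much further a longer chain on that branched carbon would move the number.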